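The source may hold more compounds than are shown below. What is called first, only, known or untested is meant among the compounds shown, and "the series" means these compounds.

Measured so far in a functional assay on cardiac atrium for antagonist activity at histamine H2 receptor (Cavia porcellus); on this read-out higher numbers stand for weaker binding and lower numbers for tighter binding:
compound 2, `CC(=O)/N=C(\N)NCCCc1c[nH]cn1`: 363 nM
compound 1, `N/C(=N\C(=O)CCc1c[nH]c2ccccc12)NCCCc1c[nH]cn1`: 437 nM

Compound 2 shows the lower of the two numbers in this assay, yet compound 1 gives 437 nM and the two values lie within the scatter of each other. Compound 3, `CCCC(=O)/N=C(\N)NCCCc1c[nH]cn1`, has not been measured. It differs from compound 2 by ethyl in place of hydrogen on a saturated chain carbon bound to a carbonyl carbon. For the measured compounds named here, no measured pair shows a change of this kind, so no step size is known. Compound 3 is expected to give 300 nM (range 120 nM to 750 nM). The expected step of a 1.2-fold lower number from compound 2 to compound 3 (0.08 log units; within the scatter) is estimated to stay within the scatter, with no clear direction.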

Compound 3, dissociation constant: 407 nM
Beside the measured number, compound 3's estimate is 1.4-fold (0.13 log units) below it; measured number inside the range.
By their numbers in this assay, from the lowest: compounds 2, 3 and 1 (each within the scatter of the next).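

In this assay, the change from methyl to propyl on a saturated chain carbon bound to a carbonyl carbon gives the first step read at this position (a 1.1-fold higher number from compound 2 to compound 3 (0.05 log units; within the scatter)). Ethyl in place of hydrogen at this place therefore leaves the number within the scatter, with no direction that can be read from this single pair. Nothing available bears on why the number holds here. On these data alone, whether a longer chain, an amine or a carboxylic acid at this place would carry the number beyond the scatter remains open.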